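Replacing the quinoline on the amide-bearing chain carbon

The compounds below may be only part of what the source reports. "The series", "measured", "known", "first", "only" and "open" are said of these compounds alone.

Compound 1 `O=C(O)C[C@H](NC(=O)CCCCc1ccc2c(n1)NCCC2)c1cnc2ccccc2c1`: 4440 nM
Compound 2 `O=C(O)C[C@H](NC(=O)CCCCc1ccc2c(n1)NCCC2)c1cncnc1`: > 10000 nM

Within the data shown here, compound 1 holds the only actual number in a functional assay for inhibition, with Homo sapiens as the target (on this read-out higher numbers stand for weaker inhibition and lower numbers for stronger inhibition), giving 4440 nM. Compound 2 reaches only the assay limit of > 10000 nM, and for compound 2 that is the limit of > 10000 nM in this assay, at which 1 of the 2 values shown sits. Among the measured compounds shown here, the step of an at least 2.2-fold higher number from compound 1 to compound 2 (0.35 log units; beyond the scatter) is the sole measured comparison and shows inhibition weakening when the bicycle gives way to a single ring. Compound 3 `O=C(O)C[C@H](NC(=O)CCCCc1ccc2c(n1)NCCC2)c1ccc2nc(O)oc2c1` keeps a bicycle: 2-hydroxy-1,3-benzoxazol-6-yl in place of quinolin-3-yl on a saturated chain carbon bound to an amide-type nitrogen and a saturated chain carbon. That step therefore bears only loosely on it, and no change beyond the scatter is expected, a 1.1-fold lower number from compound 1 to compound 3 (0.05 log units; within the scatter). Compound 3 is estimated at 4000 nM, expected between 1000 nM and 16000 nM.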

Compound 3, half-maximal inhibitory concentration: > 10000 nM
Compound 3 gave a limit, no number; the forecaster's own chance of this, stated with the estimate: 30%; middle value at least 2.5-fold (0.39 log units) away from the limit.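

Keeping a bicycle is not enough at this position: exchanging quinolin-3-yl for 2-hydroxy-1,3-benzoxazol-6-yl gives an at least 2.2-fold higher number from compound 1 to compound 3 (0.35 log units; beyond the scatter). Among these compounds, compound 3 yields only a limit, and quinolin-3-yl remains the sole group here with an actual number: the limit of > 10000 nM in this assay, at which 2 of the 3 values shown sit. The steps between compound 2 and compound 3 cannot be read, since both values are limits.

Open, as far as these compounds go, is whether a naphthalen-2-yl or a plain phenyl at this position would give a number, and how the two groups at the limit truly differ.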